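The source may hold more compounds than are shown below. What is called first, only, known or untested is meant among the compounds shown, and "the series" means these compounds.

For the measured compounds named here, in a functional assay on MCF7 cells (Homo sapiens) for inhibition, read by MTT assay, with a stated time of 48 h (a higher number here means a weaker inhibitor, a lower number a stronger inhibitor), compound 1 (`Fc1ccc(CSc2nnc(-c3ccncc3)n2-c2ccccc2)cc1`) gives 21100 nM, and compound 2 (`Brc1ccc(CSc2nnc(-c3ccncc3)n2-c2ccccc2)cc1`) gives 12600 nM, so compound 2 stands within the scatter of the only other measured compound. Compound 3 (`Fc1cccc(F)c1CSc1nnc(-c2ccncc2)n1-c1ccccc1`) carries 2,6-difluorophenyl in place of 4-bromophenyl on a saturated chain carbon bound to a sulfur. Going by the values given here, the one measured step that bears on this, bromo in place of fluoro, is a 1.7-fold lower number from compound 1 to compound 2 (0.22 log units; within the scatter). It offers only partial guidance, and no step beyond the scatter is expected in this assay. The expected change is a 1.2-fold higher number from compound 2 to compound 3 (0.08 log units; within the scatter). For compound 3 the estimate is 15000 nM, with an expected range of 7000 nM to 32000 nM.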

Compound 3, half-maximal inhibitory concentration: > 50000 nM
Compound 3: only a limit was reported (the forecaster's own chance of this, stated with the estimate: 5%); middle value at least 3.3-fold (0.52 log units) from the limit.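

In this assay, the aromatic group on the saturated chain carbon bound to a sulfur proves able to move the number beyond the scatter: 2,6-difluorophenyl in place of 4-bromophenyl gives an at least 3.9-fold higher number from compound 2 to compound 3 (0.59 log units; beyond the scatter) and 2,6-difluorophenyl in place of 4-fluorophenyl gives an at least 2.3-fold higher number from compound 1 to compound 3 (0.37 log units; beyond the scatter), whereas the bromo-for-fluoro step stayed within the scatter. As far as these compounds go, the number for compound 3 is only a limit of the assay, so the full size of both steps stays unknown: the limit of > 50000 nM in this assay, at which 1 of the 3 values shown sits.

The compounds shown leave open whether the second fluoro group or the placement of the fluoro groups in 2,6-difluorophenyl accounts for the change. They also leave open how a methoxy group or an amine on this ring would read in this assay.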